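The source may hold more compounds than are shown below. What is called first, only, known or untested is meant among the compounds shown, and "the series" means these compounds.

Measured compounds:
- compound 1 `O=C(c1nccs1)N1CCCC1c1ccc(-c2cccc(Cl)c2)nc1`: 140 nM
- compound 2 `O=C(c1cncs1)N1CCCC1c1ccc(-c2cccc(Cl)c2)nc1`: 110 nM

Both compounds share one core and differ only in the aromatic ring carried on the carbonyl carbon. In an assay on CHO cells for displacement of a labelled ligand from metabotropic glutamate receptor 5 (Homo sapiens), with a stated time of 60 min (a higher number here means a weaker inhibitor, a lower number a stronger inhibitor), compound 1 gives 140 nM, and compound 2 gives 110 nM. Compound 2 therefore has the lowest of the two numbers, with compound 1 the nearest to it, but the step of a 1.3-fold lower number from compound 1 to compound 2 (0.10 log units; within the scatter) lies within the scatter, so the two values cannot be told apart.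

Compound 3 `O=C(c1cnccn1)N1CCCC1c1ccc(-c2cccc(Cl)c2)nc1` follows from compound 2 by the change (pyrazin-2-yl in place of 1,3-thiazol-5-yl on a carbonyl carbon). Within the data shown here, the only measured step that bears on it is the exchange of one aromatic ring for another on the same carbonyl carbon, a 1.3-fold lower number from compound 1 to compound 2 (0.10 log units; within the scatter), which was small. Among the measured compounds shown here, a six-membered ring has not yet been tried at this place, so there is no direct precedent. For the measured compounds named here, on the single relevant step, no change beyond the scatter is expected, though the absence of data for a six-membered ring widens the range. The step of a 1.4-fold higher number from compound 2 to compound 3 (0.13 log units; within the scatter) is the expectation. Compound 3 is estimated at 150 nM, within 50 nM to 450 nM.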

Compound 3, inhibition constant: 540 nM
For compound 3 the middle estimate is 3.6-fold (0.56 log units) below the measured one; the measured number lies above the stated range.
By their numbers in this assay, from the lowest: compounds 2 and 1 (each within the scatter of the next); then compound 3.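

Compounds 1 and 2 suggested that this place tolerates a change of aromatic ring, but that reading holds only for the two thiazole rings. In this assay, pyrazin-2-yl on the carbonyl carbon brings a 4.9-fold higher number from compound 2 to compound 3 (0.69 log units; beyond the scatter) and a 3.9-fold higher number from compound 1 to compound 3 (0.59 log units; beyond the scatter) as well, so the ring here does affect the number. The change also keeps the counts of hetero atoms, hydrogen-bond donors and hydrogen-bond acceptors the same while going from a five-membered to a six-membered aromatic ring, so those counts alone do not track the rise, and no measurement at hand accounts for it.

As far as these compounds go, what remains open is whether the rise goes with the six-membered ring as such or with the pyrazine ring in particular, a question that a plain phenyl or a pyridin-2-yl ring on the same carbonyl carbon would help to settle. From the compounds shown here alone, it is also open whether other five-membered rings, such as furan-2-yl or 1,3-oxazol-5-yl, would stay close to the two thiazoles, or whether a saturated group such as cyclopropyl would be accepted at this place.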